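This account rests on a few compounds, and the source may have more. Where it says the series, first, only, none or still open, it means among the compounds named here.

Measured compounds:
- compound 1, `O=C(Nc1ccccc1C(F)(F)F)C1CCc2ccccc2N1C(=O)c1cccc(Cl)c1`: 754 nM
- compound 2, `O=C(Nc1ccccc1C(F)(F)F)C1CCc2ccccc2N1C(=O)c1ccccc1`: 8120 nM
- compound 3, `COc1ccc(NC(=O)C2CCc3ccccc3N2)cc1`: 51900 nM

All three values come from a functional assay on NUGC-3 cells (Homo sapiens) for cytotoxicity, read by sulforhodamine B assay, with a stated time of 72 h; a lower number here means a stronger inhibitor of growth, a higher number a weaker inhibitor of growth. Compound 2 gives the second highest of the three numbers in this assay; its nearest neighbour is compound 3, which gives a higher number still, and the furthest is compound 1, which gives a number far lower. For the measured compounds named here, compound 3 lacks the aroyl group on the ring nitrogen altogether and carries a different substituent on the anilide, so no single-point step can be drawn between compound 3 and either of the others; their values are simply noted side by side.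

The step under consideration leads from compound 2 to compound 4, `O=C(Nc1ccccc1C(F)(F)F)C1CCc2ccccc2N1C(=O)c1ccccc1Cl`, not yet measured in this assay. The change is chloro in place of hydrogen on an aromatic carbon, the chloro entering on an aromatic carbon of a six-membered aromatic ring of carbon only, ortho to a large group; one bond further out, the benzoyl becomes a (2-chlorophenyl)carbonyl.

Going by the values given here, one measured step bears on this: an 11-fold higher number from compound 1 to compound 2 (1.03 log units; beyond the scatter). Read in reverse, adding chloro to the benzoyl of compound 2 gave a markedly lower number, though there the chloro sat at a different carbon of the same ring. Whether a chloro placed as in compound 4 carries the same weight cannot be told from these three compounds alone.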

Compound 4, concentration for 50% growth inhibition: 2730 nM
Compound 4: the middle estimate sits 1.4-fold (0.14 log units) below what was measured, and the stated range covers the measured number.
By their numbers in this assay, from the lowest: compound 1; then compound 4; then compound 2; then compound 3.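

In this assay, chloro in place of hydrogen on an aromatic carbon, ortho to a large group, also lowers the number (a 3.0-fold lower number from compound 2 to compound 4 (0.47 log units; beyond the scatter)), so the benzoyl of compound 2 gains from chloro at more than the one carbon seen earlier. The carbon still counts, since the step with 2-chlorophenyl in place of 3-chlorophenyl on the carbonyl carbon raises the number (a 3.6-fold higher number from compound 1 to compound 4 (0.56 log units; beyond the scatter)), and this step lies beyond the scatter; within these three benzoyl-type compounds, the unsubstituted one gives the highest number and the 3-chlorophenyl one the lowest. Nothing on hand accounts for the difference between the two chloro placements.

Going by these compounds, whether the lower number belongs to chloro in particular stays open, as fluoro, methoxy or a nitrile in the place of the chloro of compound 4 could follow it or part from it. Also open, on these data alone, is whether the same chloro steps would hold with the trifluoromethyl of the anilide replaced by a methoxy or an amine.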